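Swapping the Aryl Group on the Sulfonyl Sulfur

The compounds below may be only part of what the source reports. "The series", "measured", "known", "first", "only" and "open" are said of these compounds alone.

Compound 2 `CN(c1ccc2[nH]c(-c3n[nH]c4ccccc34)cc2n1)S(=O)(=O)c1ccc(Br)cc1` has the highest number of the two measured compounds in a functional assay on HL-60 cells (Homo sapiens) for antiproliferative activity, read by MTT assay, with a stated time of 72 h (on this read-out higher numbers stand for weaker inhibition and lower numbers for stronger inhibition), giving 6240 nM; compound 1 `Cc1ccc(S(=O)(=O)N(C)c2ccc3[nH]c(-c4n[nH]c5ccccc45)cc3n2)cc1` gives 3030 nM, and the step of a 2.1-fold higher number from compound 1 to compound 2 (0.31 log units; beyond the scatter) separates them. Compound 3 `COc1ccc(S(=O)(=O)N(C)c2ccc3[nH]c(-c4n[nH]c5ccccc45)cc3n2)cc1OC` differs from compound 2 by 3,4-dimethoxyphenyl in place of 4-bromophenyl on a sulfonyl sulfur. Among the compounds with values here, no measured step replaces the whole aryl group on the sulfonyl sulfur; the only measured change at that group, a 2.1-fold higher number from compound 1 to compound 2 (0.31 log units; beyond the scatter), was modest. For compound 3 a step of similar modest size is therefore expected, a 1.6-fold lower number from compound 2 to compound 3 (0.19 log units; within the scatter), without a firm direction. Compound 3 is estimated at 4000 nM, with a likely range from 1500 nM to 12000 nM.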

Compound 3, half-maximal inhibitory concentration: 6320 nM
Beside the measured number, compound 3's estimate is 1.6-fold (0.20 log units) below it, within the range that was stated.
By their numbers in this assay, from the lowest: compound 1; then compounds 2 and 3 (each within the scatter of the next).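

In this assay, the swap of 4-bromophenyl for 3,4-dimethoxyphenyl on the sulfonyl sulfur gives a 1.0-fold higher number from compound 2 to compound 3 (0.01 log units; within the scatter), so replacing the whole aryl group, with two hydrogen-bond acceptors entering, leaves the two compounds indistinguishable. The same group compared with the 4-methylphenyl group gives a 2.1-fold higher number from compound 1 to compound 3 (0.32 log units; beyond the scatter), so of the three aryl groups shown, the 4-methylphenyl group of compound 1 gives the lowest number. No measurement here offers a reason for this. Still open, as far as these compounds go, is whether an aryl group carrying an amine or a carboxylic acid, or a longer alkyl chain in place of the aryl group, would move the number further at this position.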